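Ethoxy to phenoxy: the step to compound 4

The source may report more compounds than this note shows. Statements on the series, on what has been measured and on what is new or still open speak of the compounds shown alone.

In a functional assay on HCT-116 cells (Homo sapiens) for inhibition, read by sulforhodamine B assay, with a stated time of 48 h, tested at 50 uM (on this read-out lower numbers stand for less inhibition of growth and higher numbers for more inhibition of growth at the one concentration tested), compound 3 (`CCOc1ccc([C@@H]2CC(=O)c3cc(CC=C(C)C)c(OC)cc3O2)cc1`) gives 65%, within the scatter of compound 2 (`CCCCOc1ccc([C@@H]2CC(=O)c3cc(CC=C(C)C)c(OC)cc3O2)cc1`) at 60% and clear of compound 1 (`COc1cc2c(cc1CC=C(C)C)C(=O)C[C@@H](c1ccc(Oc3cccc([N+](=O)[O-])c3)cc1)O2`) at 46%. Compound 4 (`COc1cc2c(cc1CC=C(C)C)C(=O)C[C@@H](c1ccc(Oc3ccccc3)cc1)O2`) differs from compound 3 in one place: phenyl in place of ethyl on an oxygen on an aromatic ring. Among the compounds with values here, compound 1 is the only measured member with an aromatic ring on that oxygen. The nearest evidence runs the opposite way, with ethyl in place of 3-nitrophenyl giving a number 19 percentage points higher from compound 1 to compound 3 (beyond the scatter) and butyl in its place giving a number 14 percentage points higher from compound 1 to compound 2 (beyond the scatter). Butyl and ethyl themselves show a number 5 percentage points higher from compound 2 to compound 3 (within the scatter). Within the data shown here, no measured compound carries phenyl without the nitro group. A modest fall is therefore expected, as the estimated a number 13 percentage points lower from compound 3 to compound 4 (beyond the scatter). Compound 4 is estimated at 52%, with an expected range of 38% to 66%.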

Compound 4, percent growth inhibition at one concentration: 76%
Beside the measured number, compound 4's estimate is 24 percentage points below it; the measured number lies above the stated range.
By their numbers in this assay, from the lowest: compound 1; then compounds 2 and 3 (each within the scatter of the next); then compound 4.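

In this assay an aromatic ring on this oxygen carries no penalty: phenyl in place of ethyl gives (a number 11 percentage points higher from compound 3 to compound 4 (beyond the scatter)) and phenyl in place of butyl gives (a number 16 percentage points higher from compound 2 to compound 4 (beyond the scatter)). The low number of compound 1 therefore goes with the nitro group and not with the ring, as hydrogen in place of nitro gives (a number 30 percentage points higher from compound 1 to compound 4 (beyond the scatter)). No measurement here bears on the reason for these steps.

Open, from the compounds shown here alone, is where a benzyl group on this oxygen would fall, and whether an amine on the phenyl ring would keep the gain.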